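Glycosyl triazole oxindoles: cytotoxicity notes, phenyl to propyl

The compounds below may be only part of what the source reports. "The series", "measured", "known", "first", "only" and "open" are said of these compounds alone.

Measured compounds:
compound 1, `CC(=O)OC[C@H]1O[C@@H](n2cc(Cn3cc([N+](=O)[O-])c4ccccc43)nn2)[C@H](OC(C)=O)[C@@H](OC(C)=O)[C@@H]1OC(C)=O`, > 200000 nM (a limit of the assay)
compound 2, `CC(=O)OC[C@H]1O[C@@H](n2cc(CN3C(=O)/C(=C\c4ccccc4)c4ccccc43)nn2)[C@H](OC(C)=O)[C@@H](OC(C)=O)[C@@H]1OC(C)=O`, 33300 nM
compound 3, `CC(=O)OC[C@H]1O[C@@H](n2cc(CN3C(=O)/C(=C/c4ccccc4)c4ccccc43)nn2)[C@H](OC(C)=O)[C@@H](OC(C)=O)[C@@H]1OC(C)=O`, 37100 nM

In a functional assay on HeLa cells (Homo sapiens) for cytotoxicity, read by sulforhodamine B assay, with a stated time of 48 h (a higher number here means a weaker inhibitor, a lower number a stronger inhibitor), compound 1 returns only a limit, (the limit of > 200000 nM in this assay, at which 1 of the 3 values shown sits), and no number. Compound 2 holds the lowest of the two numbers shown, and its nearest neighbour is compound 3: the move from one to the other, a 1.1-fold higher number from compound 2 to compound 3 (0.05 log units; within the scatter), is within the scatter. Within the data shown here, these two differ only in the configuration drawn at the exocyclic double bond, (the fact that compounds 2 and 3 differ only in the configuration as drawn), so the series so far gives no measured step on what a substituent at that carbon contributes.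

Compound 4, `CCC/C=C1\C(=O)N(Cc2cn([C@@H]3O[C@H](COC(C)=O)[C@@H](OC(C)=O)[C@H](OC(C)=O)[C@H]3OC(C)=O)nn2)c2ccccc21`, is the next candidate. Relative to compound 2 the change is propyl in place of phenyl on a double-bonded chain carbon bound to a double-bonded ring carbon. Among the measured compounds shown here, no measured step touches this kind of exchange; the only step available, from compound 2 to compound 3, concerns geometry and sits within the scatter, so it gives no direction for a change of group. With the aromatic ring removed from that position and only a three-carbon chain left, a modest loss is expected rather than a gain. For compound 4 in this assay the estimate is 65000 nM, between 22000 nM and 190000 nM, which would mean an expected step of a 2.0-fold higher number from compound 2 to compound 4 (0.29 log units; within the scatter).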

Compound 4, half-maximal inhibitory concentration: 46300 nM
Estimate against measurement, compound 4: 1.4-fold (0.15 log units) above; measured number inside the range.
By their numbers in this assay, from the lowest: compounds 2, 3 and 4 (each within the scatter of the next). At a limit, above all of these: compound 1.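

In this assay, among these compounds, the exchange of phenyl for propyl on a double-bonded chain carbon bound to a double-bonded ring carbon provides the first measured step on a change of group at this position: a 1.4-fold higher number from compound 2 to compound 4 (0.14 log units; within the scatter). The earlier pair addressed only the configuration drawn at the double bond, whereas this pair shows that the aromatic ring can be replaced by an open chain without a step beyond the scatter, so for this pair an aromatic ring at this carbon is not required to keep a number of this size. No measured property in the notes bears on this step.

The compounds shown leave open whether the position stays this tolerant with a longer chain such as hexyl, or with a chain ending in an amine or a carboxylic acid. They also leave open what the opposite drawn configuration at the double bond would give with propyl in place, since the only geometry pair shown carries phenyl.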